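The source may report more compounds than this note shows. Statements on the series, on what has been measured and on what is new or still open speak of the compounds shown alone.

In a functional assay on T-24 cells (Homo sapiens) for antiproliferative activity, read by MTT assay, with a stated time of 48 h (on this read-out higher numbers stand for weaker inhibition and lower numbers for stronger inhibition), compound 1 `CN(C)c1ccc(NC(=O)Nc2cccc(CNc3nccnc3Cl)c2)cc1` gives 20200 nM. Compound 2 `O=C(Nc1cccc(CNc2nccnc2Cl)c1)NC1CCCC1` carries cyclopentyl in place of 4-(dimethylamino)phenyl on an amide-type nitrogen; in this assay compound 2 gives only a limit, > 40000 nM, so no number is known for it. The step of an at least 1.9-fold higher number from compound 1 to compound 2 (0.29 log units; that floor lies within the scatter) is all that is measured between them, and it is a floor set by the limit of > 40000 nM in this assay, at which 1 of the 2 values shown sits. Compound 3 `Cc1ccc(NC(=O)Nc2cccc(CNc3nccnc3Cl)c2)cc1C` differs from compound 2 by 3,4-dimethylphenyl in place of cyclopentyl on an amide-type nitrogen. This change is not measured directly, but it largely undoes the move from compound 1 to compound 2 by putting an aromatic ring back on that nitrogen. Among the measured compounds shown here, the single measured step of an at least 1.9-fold higher number from compound 1 to compound 2 (0.29 log units; that floor lies within the scatter) bears on it in reverse, so a fall in the number, back towards compound 1, is expected, of about an at least 2.0-fold lower number from compound 2 to compound 3 (0.30 log units; that floor lies within the scatter). Compound 3 is therefore estimated at 20000 nM in this assay, within 8000 nM to 50000 nM.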

Compound 3, half-maximal inhibitory concentration: 8930 nM
For compound 3 the middle estimate is 2.2-fold (0.35 log units) above the measured one; the measured number falls inside the stated range.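

On the amide-type nitrogen in this assay, replacing cyclopentyl with an aromatic ring gives an at least 4.4-fold lower number from compound 2 to compound 3 (0.65 log units; beyond the scatter), a change that, unlike the earlier step, lies beyond the scatter. Going by these compounds, for compound 2 the value is only a limit, so this step is a floor and its true size remains unknown: the limit of > 40000 nM in this assay, at which 1 of the 3 values shown sits. The substituents on the aromatic ring also matter, since 3,4-dimethylphenyl in place of 4-(dimethylamino)phenyl gives a 2.3-fold lower number from compound 1 to compound 3 (0.35 log units; beyond the scatter), showing that these two aromatic groups are not interchangeable here.

On these data alone, it remains open whether the gain depends on the ring being aromatic or simply on a six-membered ring, a question that cyclohexyl on this nitrogen would address. Plain phenyl would show how much the two methyl groups contribute, and 4-chlorophenyl would show whether a halogen can take their place.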